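Propanoyl replaces ethyl on the ring amine nitrogen

The compounds below may be only part of what the source reports. "The series", "measured", "known", "first", "only" and "open" are said of these compounds alone.

This account follows three bis-arylidene compounds that share one core. Compound 1 `COc1ccc(/C=C2\CNC/C(=C\c3ccc(OC)c(OC)c3)C2=O)cc1OC` carries two methoxy groups on each aryl ring, whereas compound 2 `COc1cc(/C=C2\CNC/C(=C\c3cc(OC)c(OC)c(OC)c3)C2=O)cc(OC)c1OC` and compound 3 `CCN1C/C(=C\c2cc(OC)c(OC)c(OC)c2)C(=O)/C(=C/c2cc(OC)c(OC)c(OC)c2)C1` carry three on each. In a functional assay on NCI-H460 cells (Homo sapiens) for cytotoxicity, read by MTT assay, with a stated time of 72 h (on this read-out lower numbers stand for stronger inhibition and higher numbers for weaker inhibition), compound 1 gives 6400 nM, compound 2 gives 1500 nM, and compound 3 gives 4900 nM. Compound 3 thus stands second highest of the three numbers: its nearest neighbour is compound 1, whose number lies within the scatter of it, while compound 2 lies furthest away, with a lower number beyond the scatter. Within the data shown here, the only measured step, a 3.3-fold higher number from compound 2 to compound 3 (0.51 log units; beyond the scatter), arose from ethyl in place of hydrogen on an amine nitrogen in a ring and was modest.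

Compound 4 `CCC(=O)N1C/C(=C\c2cc(OC)c(OC)c(OC)c2)C(=O)/C(=C/c2cc(OC)c(OC)c(OC)c2)C1` differs from compound 3 by propanoyl in place of ethyl on an amine nitrogen in a ring. Among the measured compounds shown here, the change sits at the same place as the measured step, but no measured pair shows an acyl group there, so the measured step offers only an indirect guide. Given that the earlier substitution at this nitrogen moved the number modestly, the expectation is a step of about a 1.2-fold higher number from compound 3 to compound 4 (0.09 log units; within the scatter) in this assay, which may lie within the scatter. Compound 4 is therefore estimated at 6000 nM, with a range from 2500 nM to 15000 nM.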

Compound 4, half-maximal inhibitory concentration: 2700 nM
Compound 4: the middle estimate sits 2.2-fold (0.35 log units) above what was measured; measured number inside the range.
By their numbers in this assay, from the lowest: compounds 2, 4, 3 and 1 (each within the scatter of the next, the first and the last beyond it).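

Among these compounds, compound 4 carries the first acyl group on the amine nitrogen in the ring, and in this assay propanoyl in place of ethyl gives a 1.8-fold lower number from compound 3 to compound 4 (0.26 log units; within the scatter), so compound 4 cannot be told apart from compound 3. Propanoyl in place of hydrogen gives a 1.8-fold higher number from compound 2 to compound 4 (0.26 log units; within the scatter), so compound 4 cannot be told apart from compound 2 either, although ethyl in place of hydrogen gave a 3.3-fold higher number from compound 2 to compound 3 (0.51 log units; beyond the scatter), a step beyond the scatter, and a group on this nitrogen therefore does not always bring a step of that kind. No measured evidence is available on what lies behind these numbers.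

The compounds shown leave open how an acetyl group, a longer acyl chain such as butanoyl, or a carboxylic acid on a chain at this nitrogen would read in this assay. They also leave open whether propanoyl on this nitrogen would give a similar result on the core of compound 1, with its two methoxy groups on each aryl ring, and whether any of these results holds in other cell lines.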